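Swapping Acetamido for Fluoro on a Bridged Core

The compounds below may be only part of what the source reports. "The series", "measured", "known", "first", "only" and "open" are said of these compounds alone.

Going by the values given here, in an assay on HEK293 cells for binding affinity to Neuronal acetylcholine receptor; alpha4/beta2 (Homo sapiens) (a lower number here means a stronger inhibitor, a higher number a weaker inhibitor), compound 2 `CC(=O)Nc1ccc2c(c1)C1CNCC2C1` gives 75 nM, the higher of the two numbers measured so far, while compound 1 `CC(=O)c1ccc2c(c1)C1CNCC2C1` gives 0.17 nM. Among the compounds with values here, the one measured step, a 440-fold higher number from compound 1 to compound 2 (2.64 log units; beyond the scatter), concerns a different exchange and bears only loosely here. Compound 3 `Fc1ccc2c(c1)C1CNCC2C1` carries fluoro in place of acetamido on an aromatic carbon. Within the data shown here, no measured step matches this change, so its direction is uncertain, and the expected step is a 7.5-fold lower number from compound 2 to compound 3 (0.88 log units; beyond the scatter). Compound 3 is estimated at 10 nM, with a likely range from 1 nM to 100 nM.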

Compound 3, inhibition constant: 1.1 nM
For compound 3 the middle estimate is 9.1-fold (0.96 log units) above the measured one; the range from low to high includes it.
By their numbers in this assay, from the lowest: compound 1; then compound 3; then compound 2.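

Putting fluoro in place of acetamido gives a 68-fold lower number from compound 2 to compound 3 (1.83 log units; beyond the scatter) on this aromatic carbon, so the weak binding of compound 2 is not shared by every group that replaces acetyl. Fluoro still falls short of acetyl, with a 6.5-fold higher number from compound 1 to compound 3 (0.81 log units; beyond the scatter) at the same place, and compound 1 keeps the lowest number of the three. Nothing available explains why these groups differ. Still open is where an amine, a nitrile or a methoxy group on this aromatic carbon would fall among these three compounds.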